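The source may report more compounds than this note shows. Statements on the series, on what has been measured and on what is new or still open speak of the compounds shown alone.

Compound 1 `N#CC1=C(N)Oc2c(c3nc4ccccc4nc3c3ccccc23)C12C(=O)N(Cc1cnnn1-c1ccccc1Cl)c1ccccc12`: in an ADME assay on HUVEC cells (Homo sapiens) for antiproliferative activity, read by MTT assay, with a stated time of 48 h (a higher number here means a weaker inhibitor, a lower number a stronger inhibitor), compound 1 gives > 50000 nM, a limit of the assay.
Compound 2 `COc1ccc(-n2nncc2CN2C(=O)C3(C(C#N)=C(N)Oc4c3c3nc5ccccc5nc3c3ccccc43)c3ccccc32)cc1`: in this assay compound 2 gives > 50000 nM, likewise a limit.

Compound 2 thus stands at the limit of this assay, where both measured values sit, as the limit of > 50000 nM in this assay, at which 2 of the 2 values shown sit, records. Going by the values given here, the only measured step, a step that the two limits leave unreadable from compound 1 to compound 2, is therefore unreadable in size. Compound 3 `N#CC1=C(N)Oc2c(c3nc4ccccc4nc3c3ccccc23)C12C(=O)N(Cc1cnnn1-c1cccc(S(N)(=O)=O)c1)c1ccccc12` differs from compound 2 by 3-sulfamoylphenyl in place of 4-methoxyphenyl on an aromatic nitrogen. Among the compounds with values here, no measured step bears on this change, and both measured compounds give only a limit, so the step of a number no higher from compound 2 to compound 3 (the limit leaves the size open) is expected to show nothing beyond the scatter. Compound 3 is accordingly estimated at 50000 nM, within 20000 nM to 200000 nM, and is expected most likely to be reported again as a limit.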

Compound 3, half-maximal inhibitory concentration: 38600 nM
The estimate for compound 3 lay 1.3-fold (0.11 log units) above the measured number, and the stated range covers the measured number.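

Going by these compounds alone, with 3-sulfamoylphenyl on the aromatic nitrogen, compound 3 gives the only actual number so far in this assay, 38600 nM, so a change at this position can bring a value inside the range of the assay. Going by these compounds, the steps are an at least 1.2-fold lower number from compound 2 to compound 3 (0.11 log units; that floor lies within the scatter) and an at least 1.2-fold lower number from compound 1 to compound 3 (0.11 log units; that floor lies within the scatter); each is only a floor, so the true size stays unknown. The other two values remain limits: the limit of > 50000 nM in this assay, at which 2 of the 3 values shown sit.

On these data alone, whether an amine or a carboxylic acid in place of the sulfamoyl group would also give a measurable number stays open.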